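A few compounds are considered here, and "the series" means these few. Any claim that something is new, unique, unknown or untested is made for them only; others in the source may bear on it.

Compound 1, whose structure is `CNc1nc(SC)nc2c1ncn2[C@@H]1C[C@@H](O)[C@H](CO)O1`, is the starting point. In a functional assay on Raji cells (Homo sapiens) (on this read-out higher numbers stand for weaker inhibition and lower numbers for stronger inhibition), compound 1 gives > 300 uM, which is a limit of the assay rather than a measured number. For the measured compounds named here, the only measured neighbour is compound 2, with the structure `CNc1nc(Br)nc2c1ncn2[C@@H]1C[C@@H](O)[C@H](CO)O1`, in which a bromo group replaces the methylsulfanyl group on an aromatic carbon; in this assay compound 2 gives 80 uM, and the step is an at least 3.7-fold lower number from compound 1 to compound 2 (0.57 log units; beyond the scatter). The unmeasured compound 3 has the structure `CSc1nc(N)c2ncn([C@@H]3C[C@@H](O)[C@H](CO)O3)c2n1` and differs from compound 1 by hydrogen in place of methyl on a nitrogen on an aromatic ring. No measured step touches that nitrogen, so the step from compound 1 to compound 2 gives no direct guide, and the standing of compound 1 is shown only by the limit of > 300 uM in this assay, at which 1 of the 2 values shown sits. For compound 3 the expected step is therefore a step that the limit leaves unreadable from compound 1 to compound 3, with nothing beyond the scatter anticipated. The estimate for compound 3 is 400 uM, within a range from 100 uM to 1500 uM.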

Compound 3, concentration for 50% inhibition: 107 uM
Beside the measured number, compound 3's estimate is 3.7-fold (0.57 log units) above it; the measured number falls inside the stated range.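

Taking the methyl off the nitrogen on the aromatic ring, the change from methylamino to amino, gives an at least 2.8-fold lower number from compound 1 to compound 3 (0.44 log units; beyond the scatter) in this assay. The read-out therefore responds to this nitrogen as well as to the place where compound 2 carries its bromo group, something the earlier pair could not show, as it changed only the methylsulfanyl group. The full size of this step stays unknown because compound 1 stands at a limit rather than at a measured number: the limit of > 300 uM in this assay, at which 1 of the 3 values shown sits.

Going by these compounds, whether a longer chain on this nitrogen, such as ethyl, or a second methyl, as in dimethylamino, would give a higher or lower number remains open. Also open, on these data alone, is how the amino and bromo groups would behave together in a single compound.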